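Working notes: allyl to benzyl on the shared core

This account rests on a few compounds, and the source may have more. Where it says the series, first, only, none or still open, it means among the compounds named here.

Measured compounds:
compound 1 `C=CCOC(=O)Nc1ccc([Se]C#N)cc1`: 68600 nM
compound 2 `N#C[Se]c1ccc(NC(=O)Oc2ccccc2)cc1`: 73200 nM

In a functional assay on CCRF-CEM cells (Homo sapiens) for cytotoxicity, read by MTT assay, with a stated time of 72 h (a lower number here means that less compound is tolerated, a higher number that more compound is tolerated), compound 1 gives 68600 nM, the lowest of the two numbers in hand; compound 2 gives 73200 nM, and the step of a 1.1-fold higher number from compound 1 to compound 2 (0.03 log units; within the scatter) lies within the scatter, so the two values cannot be told apart.

Compound 3 `N#C[Se]c1ccc(NC(=O)OCc2ccccc2)cc1` is unmeasured. Its difference from compound 1 is phenyl in place of vinyl on a saturated chain carbon bound to an oxygen next to a carbonyl group. Among the measured compounds shown here, the only measured step that bears on this position is a 1.1-fold higher number from compound 1 to compound 2 (0.03 log units; within the scatter), where a phenyl took the place of the whole allyl on the oxygen next to the carbonyl group without any change beyond the scatter. The change to compound 3 keeps the saturated chain carbon and exchanges only the vinyl for phenyl, a smaller alteration at the same site. With one step at this site showing no movement, no step beyond the scatter is expected in this assay for compound 3.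

Compound 3 is therefore expected at 70000 nM, a step of a 1.0-fold higher number from compound 1 to compound 3 (0.01 log units; within the scatter), with a range from 35000 nM to 140000 nM that reflects only the ordinary spread of such a measurement.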

Compound 3, concentration lethal to 50% of the cells: 73700 nM
For compound 3 the middle estimate is 1.1-fold (0.02 log units) below the measured one, and the stated range covers the measured number.
By their numbers in this assay, from the lowest: compounds 1, 2 and 3 (each within the scatter of the next).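

In this assay the step of a 1.1-fold higher number from compound 1 to compound 3 (0.03 log units; within the scatter) shows that a phenyl can take the place of the vinyl on a saturated chain carbon bound to an oxygen next to a carbonyl group with no readable change, although the entering group carries 6 heavy atoms and one six-membered aromatic ring against 2 heavy atoms and no ring for the group that leaves. Compound 2 had lost the saturated chain carbon along with the vinyl, whereas compound 3 keeps it, so the phenyl has now been seen at this site both with and without that carbon, and neither compound stands beyond the scatter from compound 1. No measurement in hand accounts for this lack of movement.

The compounds shown leave open whether a group of a different kind on this oxygen, such as an amine or a carboxylic acid carried on the chain, or a longer chain than the allyl, would shift the number beyond the scatter. From the compounds shown here alone, all three keep the shared core, so the effect of any change elsewhere on it remains unknown.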